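A few compounds are considered here, and "the series" means these few. Any claim that something is new, unique, unknown or untested is made for them only; others in the source may bear on it.

Measured in an ADME assay on Vero cells (Chlorocebus sabaeus) for cytotoxicity, with a stated time of 7 days; a higher number here means that more compound is tolerated, a lower number that less compound is tolerated:
- compound 1 `COc1ccc2[nH]c(C(=O)N3CC(=O)N(Cc4ccccc4)[C@@H](CCc4ccccc4)C3)cc2c1`: > 30000 nM, a limit
- compound 2 `COc1ccc2[nH]c(C(=O)N3CC(=O)N(Cc4ccoc4)[C@@H](Cc4ccccc4)C3)cc2c1`: > 10000 nM, a limit
- compound 3 `COc1ccc2[nH]c(C(=O)N3CC(=O)N(c4ccccc4)[C@@H](Cc4ccccc4)C3)cc2c1`: > 30000 nM, a limit

Compound 1 gives no number, only a limit. It stands at the limit of > 30000 nM in this assay, at which 2 of the 3 values shown sit, together with compound 3. Compound 2 stands at the limit of > 10000 nM in this assay, at which 1 of the 3 values shown sits. None of the three compounds therefore has an actual half-maximal cytotoxic concentration to compare.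

Compound 4 `COc1ccc2[nH]c(C(=O)N3CC(=O)N(Cc4ccccc4)[C@@H](COC(C)(C)C)C3)cc2c1` differs from compound 1 in one place: tert-butoxy in place of benzyl on a saturated chain carbon bound to a saturated ring carbon. In words, tert-butoxy comes in place of benzyl on a saturated chain carbon bound to a saturated ring carbon. Cut one bond further out, the same difference reads phenethyl to (tert-butoxy)methyl.

Going by the values given here, only one measured step is available, a step that the two limits leave unreadable from compound 2 to compound 3. It concerns a different place, an amide-type nitrogen in a ring, and it gives no size to carry over. Among the compounds with values here, no measured step changes the group at the place altered in compound 4. The expectation therefore rests on compound 1, which stands at > 30000 nM, a limit.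

In this assay, the expected result is a number no higher from compound 1 to compound 4 (the limit leaves the size open), which means no step beyond the scatter, and a further limit is the likely report. The estimated value for compound 4 is 30000 nM, with an expected range from 10000 nM to 60000 nM.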

Compound 4, half-maximal cytotoxic concentration: 78200 nM
Compound 4: middle estimate off by 2.6-fold (0.42 log units), on the low side; the measured number lies above the stated range.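

Compound 4 gives an actual number in this assay, but compound 1 has only a limit, so no new step can be read from tert-butoxy in place of benzyl. The compounds shown leave open where the half-maximal cytotoxic concentrations of compound 1, compound 2 and compound 3 actually lie, and whether either change shown alters them.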